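Aryl variation at the carbon double-bonded to ring nitrogen

This account rests on a few compounds, and the source may have more. Where it says the series, first, only, none or still open, it means among the compounds named here.

compound 1 `COc1cc(C2CC(c3ccccc3)=NN2C(C)=O)ccc1OCc1cn(Cc2ccc([N+](=O)[O-])cc2)nn1`: 7%
compound 2 `COc1cc(C2CC(c3cc(OC)c(OC)c(OC)c3)=NN2C(C)=O)ccc1OCc1cn(Cc2ccc([N+](=O)[O-])cc2)nn1`: 60%

Within the data shown here, in a functional assay on COLO 205 cells (Homo sapiens) for inhibition, read by sulforhodamine B assay, tested at 10 uM (on this read-out lower numbers stand for less inhibition of growth and higher numbers for more inhibition of growth at the one concentration tested), compound 1 gives 7%, and compound 2 gives 60%, the higher of the two numbers so far. Among the measured compounds shown here, the single measured step, a number 53 percentage points higher from compound 1 to compound 2 (beyond the scatter), is the only guide to what the aryl group at this carbon does.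

Compound 3 `COc1cc(C2CC(c3cccc4ccccc34)=NN2C(C)=O)ccc1OCc1cn(Cc2ccc([N+](=O)[O-])cc2)nn1` differs from compound 2 by naphthalen-1-yl in place of 3,4,5-trimethoxyphenyl on a carbon with a double bond to nitrogen. The measured step bears on it only loosely: it shows that the group at this carbon can shift the read-out by a large amount, but naphthalen-1-yl resembles neither of the two measured groups, so the direction is open. Since only the unsubstituted phenyl analogue, compound 1, sits low, a fall from compound 2 is judged more likely than a further rise, but with wide uncertainty.

For compound 3 a value of 30% is expected, with a range of 5% to 60%. This estimate corresponds to an expected step of a number 30 percentage points lower from compound 2 to compound 3 (beyond the scatter).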

Compound 3, percent growth inhibition at one concentration: 46%
Estimate against measurement, compound 3: 16 percentage points below; low and high end bracket the measured number.
By their numbers in this assay, from the lowest: compound 1; then compound 3; then compound 2.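

In this assay, naphthalen-1-yl in place of phenyl gives a number 39 percentage points higher from compound 1 to compound 3 (beyond the scatter), so a large rise at this carbon also occurs with a group that carries no oxygen and no hydrogen-bond acceptors. The methoxy groups of 3,4,5-trimethoxyphenyl are therefore not the only route to a higher read-out here. The two replacements are still not equal, since naphthalen-1-yl in place of 3,4,5-trimethoxyphenyl gives a number 14 percentage points lower from compound 2 to compound 3 (beyond the scatter). No measurement at hand accounts for these differences.

Open, as far as these compounds go, is whether a single methoxy group on the phenyl would raise the read-out, and how a chloro substituent or a pyridin-3-yl group at this carbon would compare. Also open, from the compounds shown here alone, is how compound 2 and compound 3 would rank at other concentrations.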